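This account rests on a few compounds, and the source may have more. Where it says the series, first, only, none or still open, it means among the compounds named here.

Compound 1 `COc1ccc(-c2cnc(NC(=O)c3ccccc3OC)n2C)cc1` is one of three compounds that have been tested in a toxicity assay on THP-1 cells (Homo sapiens) for inhibition; on this read-out higher numbers stand for lower toxicity in this test and lower numbers for higher toxicity in this test. In this assay compound 1 gives > 100000 nM, which is a limit of the test rather than a number. Compound 2 `COc1ccc(-c2nc3ncc(-c4ccc(F)cc4)cc3[nH]2)cc1` also sits at a limit in this assay, giving > 100000 nM. Compound 3 `Cc1ccc(C(=O)Nc2ncc(-c3ccccc3)o2)cc1` is built differently and gives 26000 nM in this assay, a number rather than a limit. Compound 1 thus stands at the limit of > 100000 nM in this assay, at which 2 of the 3 values shown sit, and its figure cannot be placed more exactly than that.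

Compound 4 `COc1ccc(-c2cnc(NC(=O)c3ccc(Cl)cc3)n2C)cc1` has not yet been measured. It differs from compound 1 in one place, (4-chlorophenyl in place of 2-methoxyphenyl on a carbonyl carbon). Among the compounds with values here, no measured pair among the three compounds shows a change of this kind, so nothing measured tells how large its effect in this assay might be. The expectation is a step from compound 1 to compound 4 of about an at least 1.1-fold lower number from compound 1 to compound 4 (0.04 log units; that floor lies within the scatter), which is none beyond the scatter. Compound 4 is therefore expected to give around 90000 nM in this assay, within a range from 30000 nM to 200000 nM, and the result may well again be a limit rather than a number.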

Compound 4, half-maximal cytotoxic concentration: > 100000 nM
Compound 4: only a limit was reported (the forecaster's own chance of this, stated with the estimate: 60%); middle value at least 1.1-fold (0.04 log units) away from the limit.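

Compound 4 gives > 100000 nM in this assay, which is a limit rather than a number. Compound 1 also sits at a limit, so no step between these two compounds can be read: the limit of > 100000 nM in this assay, at which 3 of the 4 values shown sit.

The compounds shown leave open whether 4-chlorophenyl in place of 2-methoxyphenyl changes the value in this assay at all.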